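Methylsulfanyl in place of methyl on the shared core

A few compounds are considered here, and "the series" means these few. Any claim that something is new, unique, unknown or untested is made for them only; others in the source may bear on it.

Compound 2 `Cc1ncnc2c1c(-c1ccoc1)cn2[C@@H]1O[C@H](CO)[C@@H](O)[C@H]1O` carries a furan-3-yl group on the shared core. In a functional assay on HCT-116 cells (Homo sapiens), read by MTT assay, with a stated time of 72 h (a lower number here means a stronger inhibitor, a higher number a weaker inhibitor), compound 2 gives only a limit, > 20000 nM. Compound 1 `Cc1ncnc2c1c(-c1cc3ccccc3o1)cn2[C@@H]1O[C@H](CO)[C@@H](O)[C@H]1O`, with 1-benzofuran-2-yl in that place, also gives only a limit in this assay, > 20000 nM. Among the measured compounds shown here, compound 3 `Cc1ncnc2c1c(I)cn2[C@@H]1O[C@H](CO)[C@@H](O)[C@H]1O`, with iodo there, is the one compound with a number: in this assay compound 3 gives 4720 nM. Hence the step of an at least 4.2-fold lower number from compound 2 to compound 3 (0.62 log units; beyond the scatter) and the step of an at least 4.2-fold lower number from compound 1 to compound 3 (0.62 log units; beyond the scatter), while a step that the two limits leave unreadable from compound 1 to compound 2. Compound 2 therefore sits at the limit of > 20000 nM in this assay, at which 2 of the 3 values shown sit.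

Compound 4 `CSc1ncnc2c1c(-c1ccoc1)cn2[C@@H]1O[C@H](CO)[C@@H](O)[C@H]1O` differs from compound 2 elsewhere: methylsulfanyl in place of methyl on an aromatic carbon. All three measured steps exchange the group on the other aromatic carbon, so none of them bears on this change, and nothing shown points to a large gain or loss. Since compound 2 gives only a limit, the expected step is a step that the limit leaves unreadable from compound 2 to compound 4. Compound 4 is expected to give 25000 nM, between 8000 nM and 80000 nM, most likely again reported only as a limit.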

Compound 4, half-maximal inhibitory concentration: 40 nM
Compound 4: the middle estimate sits 630-fold (2.80 log units) above what was measured; the whole stated range lies above it.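

In this assay, among the compounds shown here, methylsulfanyl in place of methyl gives an at least 500-fold lower number from compound 2 to compound 4 (2.69 log units; beyond the scatter), so the aromatic carbon next to the ring nitrogen proves to be a highly sensitive place on the shared core, which the earlier steps could not show as they all exchanged the group on the other aromatic carbon. Furan-3-yl stands in both compounds, so this group does not by itself rule out strong inhibition of these cells. The step gives only a minimum size, because compound 2 has only a limit as its value: the limit of > 20000 nM in this assay, at which 2 of the 4 values shown sit.

The compounds shown leave open whether a methoxy group, an amine or a longer chain such as ethylsulfanyl would work in place of methylsulfanyl. They also leave open whether methylsulfanyl brings a similar gain alongside iodo or 1-benzofuran-2-yl on the other aromatic carbon.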